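The source may report more compounds than this note shows. Statements on the series, on what has been measured and on what is new or still open speak of the compounds shown alone.

Measured in a functional assay on MKN-28 cells (Homo sapiens) for cytotoxicity, read by MTT assay; on this read-out higher numbers stand for weaker inhibition and lower numbers for stronger inhibition:
- compound 1 `C=C1C(=O)[C@]23C[C@@]1(O)CC[C@H]2[C@@]12C=CC(=O)[C@](C)(C(=O)O1)[C@H]2[C@@H]3C(=O)OCc1ccccc1`: 2500 nM
- compound 2 `C=C1C(=O)[C@]23C[C@@]1(OCC)CC[C@H]2[C@@]12C=CC(=O)[C@](C)(C(=O)O1)[C@H]2[C@@H]3C(=O)OCc1ccccc1`: 16500 nM
- compound 3 `C=C1C(=O)[C@]23C[C@@]1(OC)CC[C@H]2[C@@]12C=CC(=O)[C@](C)(C(=O)O1)[C@H]2[C@@H]3C(=O)OC`: 3400 nM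

Compound 3, at 3400 nM, lies within the scatter of compound 1, while compound 2 gives a clearly higher number at 16500 nM.

Compound 4 `C=C1C(=O)[C@]23C[C@@]1(OC)CC[C@H]2[C@@]12C=CC(=O)[C@](C)(C(=O)O1)[C@H]2[C@@H]3C(=O)OCc1ccccc1` is not yet measured. It differs from compound 3 by phenyl in place of hydrogen on a saturated chain carbon bound to an oxygen next to a carbonyl group, which amounts to methoxycarbonyl to benzyloxycarbonyl. The methoxy group of compound 3 stays.

Among the measured compounds shown here, no measured step covers this change directly. The only one, a 6.6-fold higher number from compound 1 to compound 2 (0.82 log units; beyond the scatter), is a modest step and concerns ethyl in place of hydrogen on an oxygen on a saturated carbon. It bears only indirectly, since compound 1 and compound 2 both carry the benzyloxycarbonyl group of compound 4. On that oxygen, compound 4 has methyl, whereas compound 1 has hydrogen and compound 2 has ethyl. Its number is therefore expected to fall between those of compound 1, at 2500 nM, and compound 2, at 16500 nM, nearer the lower end.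

The expected change is a small one towards a higher number, not beyond the scatter, with an estimated 1.8-fold higher number from compound 3 to compound 4 (0.25 log units; within the scatter). For compound 4 the estimated value is 6000 nM, with an expected range from 2500 nM to 15000 nM.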

Compound 4, half-maximal inhibitory concentration: 800 nM
Compound 4: the middle estimate sits 7.5-fold (0.88 log units) above what was measured; measured number outside the range, below it.
By their numbers in this assay, from the lowest: compound 4; then compounds 1 and 3 (each within the scatter of the next); then compound 2.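

In this assay, phenyl on the saturated chain carbon bound to an oxygen next to a carbonyl group, which turns methoxycarbonyl into benzyloxycarbonyl, goes with a lower number while the methoxy group stays fixed (a 4.3-fold lower number from compound 3 to compound 4 (0.63 log units; beyond the scatter)). With benzyloxycarbonyl held constant, the substituent on the oxygen on a saturated carbon does not give a steady rise with chain size: methyl in place of hydrogen lowers the number (a 3.1-fold lower number from compound 1 to compound 4 (0.49 log units; beyond the scatter)), and methyl rather than ethyl lowers it much further (a 21-fold lower number from compound 2 to compound 4 (1.31 log units; beyond the scatter)), leaving compound 4 lowest of the compounds shown, with all its steps beyond the scatter. No data on the cause of these steps accompany the series.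

Going by these compounds, it remains open whether the lower number requires the phenyl ring itself or would also follow from a longer chain, such as butyl, or a pyridine ring in its place on that ester. On these data alone, on the oxygen on a saturated carbon, the effect of a propyl or acetyl group is also open, as is whether the methyl preference carries over to the methoxycarbonyl compounds.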